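Chain in Place of Ring on the Amide of Compound 2

This account rests on a few compounds, and the source may have more. Where it says the series, first, only, none or still open, it means among the compounds named here.

Measured compounds: compound 1 `CCCCNC(=O)C1CCCN(c2nc(N)c3cc(OC)c(OC)cc3n2)C1`, 8.25 nM; compound 2 `COc1cc2nc(N3CCC(C(=O)NC4CCCC4)CC3)nc(N)c2cc1OC`, 0.63 nM; compound 3 `CCN(CC)C(=O)C1CCCN(c2nc(N)c3cc(OC)c(OC)cc3n2)C1`, 117 nM.

In an assay on isolated protein for displacement of a labelled ligand from Adrenergic receptor alpha-1 (Rattus norvegicus) (a lower number here means a stronger inhibitor, a higher number a weaker inhibitor), compound 2 gives the lowest number of the three, with compound 1 next and compound 3 furthest away. Compound 4 `CCCCNC(=O)CC1CCN(c2nc(N)c3cc(OC)c(OC)cc3n2)CC1` differs from compound 2 in one place: (butylcarbamoyl)methyl in place of cyclopentylcarbamoyl on a saturated ring carbon. For the measured compounds named here, no measured pair shows exactly this exchange; the only step on an amide substituent, a 14-fold higher number from compound 1 to compound 3 (1.15 log units; beyond the scatter), shows that changes at the carbonyl nitrogen can move the number a great deal. Compound 1 and compound 2 show that a butylamide on this core can still give a low number. For compound 4 a moderate rise is expected, a 4.8-fold higher number from compound 2 to compound 4 (0.68 log units; beyond the scatter), so compound 4 is estimated at 3 nM with a range from 0.8 nM to 12 nM.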

Compound 4, inhibition constant: 1.4 nM
The estimate for compound 4 lay 2.1-fold (0.33 log units) above the measured number; low and high end bracket the measured number.
By their numbers in this assay, from the lowest: compound 2; then compound 4; then compound 1; then compound 3.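

In this assay the exchange of cyclopentylcarbamoyl for (butylcarbamoyl)methyl gives a 2.2-fold higher number from compound 2 to compound 4 (0.35 log units; beyond the scatter) and so only a modest step. For the compounds shown here, at this saturated ring carbon, then, an open chain can replace the five-membered carbon ring and the number stays low, which the earlier compounds did not show.

The compounds shown do not separate the loss of the ring from the added methyl link, since neither butylcarbamoyl nor (cyclopentylcarbamoyl)methyl appears at this place. From the compounds shown here alone, it also stays open how a longer chain such as hexyl, or an amine at the end of the butyl chain, would fare. Nothing at hand accounts for the size of this step.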